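Benzyl for Phenyl on a Fused Core

The source may hold more compounds than are shown below. What is called first, only, known or untested is meant among the compounds shown, and "the series" means these compounds.

Among the measured compounds shown here, compound 1 `COc1ccc(-n2cc3nc(-c4ccccc4)nc(N)c3n2)cc1` is one of three compounds measured in an assay on CHO cells for displacement of a labelled ligand from adenosine receptor A1 (Homo sapiens), read by scintillation counting, with a stated time of 120 min, tested at 1 uM (on this read-out lower numbers stand for less inhibition and higher numbers for more inhibition at the one concentration tested (going by the name of the read-out)), where compound 1 gives 12%. Compound 3 `COc1ccc(-n2cc3nc(C)nc(NC(=O)Nc4ccccc4)c3n2)cc1` gives 5% in this assay, and compound 2 `O=C(c1ccco1)N(C(=O)c1ccco1)c1nc(-c2ccccc2)nc2cn(-c3ccccc3)nc12` gives 3%. Compound 1 has the highest number of the three, but its gaps to compound 3 and to compound 2 both lie within the scatter of repeated measurements, so no order among them can be claimed; all three show little inhibition at the single concentration tested.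

Compound 4 `COc1ccc(-n2cc3nc(Cc4ccccc4)nc(N)c3n2)cc1` has not yet been measured. It differs from compound 1 in one place: benzyl in place of phenyl on an aromatic carbon. For the measured compounds named here, no pair of measured compounds shows what such a change does in this assay, so there is nothing to read a direction from. Since compound 1 already sits near the bottom of the read-out at 12%, the step from compound 1 to compound 4 is expected to be small, a number 2 percentage points lower from compound 1 to compound 4 (within the scatter), and not beyond the scatter. Compound 4 is therefore estimated at 10%, within a range from 0% to 28%.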

Compound 4, a percentage reported as inhibition, at one concentration (the size of the read-out at that concentration, not a potency): 40%
For compound 4 the middle estimate is 30 percentage points below the measured one; measured number outside the range, above it.
By their numbers in this assay, from the lowest: compounds 2, 3 and 1 (each within the scatter of the next); then compound 4.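

Among the compounds shown here, the position on the six-membered aromatic ring with 2 nitrogen, between two ring nitrogen atoms, does respond in this assay: benzyl in place of phenyl gives a number 28 percentage points higher from compound 1 to compound 4 (beyond the scatter) and is the first step here to clear the scatter. The change is small on paper, since benzyl, with 7 heavy atoms against 6 for phenyl, keeps the same six-membered aromatic ring of carbon only and adds no hydrogen-bond donors or acceptors, so a small edit at this spot can be enough to move the number. No measurement at hand explains the rise.

From the compounds shown here alone, it remains open whether a longer chain such as phenethyl would move the number further in the same direction. A single step also cannot show whether the number would be higher, lower or level with an amine on the same carbon chain, or whether this gain would hold on other compounds.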